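The source may hold more compounds than are shown below. What is called first, only, known or untested is meant among the compounds shown, and "the series" means these compounds.

Measured in an ADME assay on THP-1 cells (Homo sapiens) for cytotoxicity, read by flow cytometry and propidium iodide staining, with a stated time of 72 h; a higher number here means a weaker inhibitor, a lower number a stronger inhibitor:
- compound 1 `COc1cccc(-c2cc(=O)c3cc(NC(C)=O)ccc3o2)c1`: 10000 nM
- compound 2 `CC(=O)Nc1ccc2oc(-c3ccccc3)c(O)c(=O)c2c1`: 36000 nM
- compound 3 `COc1ccccc1-c1oc2ccc(NC(C)=O)cc2c(=O)c1O`: > 125000 nM (a limit, not a number)

Compound 3 stands at the limit of > 125000 nM in this assay, at which 1 of the 3 values shown sits. Compound 4 `COc1cccc(-c2oc3ccc(NC(C)=O)cc3c(=O)c2O)c1` has the same atoms joined differently, with 3-methoxyphenyl in place of 2-methoxyphenyl on an aromatic carbon. The nearest measured step is an at least 3.4-fold higher number from compound 2 to compound 3 (0.54 log units; beyond the scatter), which adds the methoxy group and is beyond the scatter. Moving that methoxy group has not been measured, but compound 1, which also carries 3-methoxyphenyl, gives 10000 nM. A modest drop towards the number of compound 2 therefore seems likely. The expected change is an at least 2.2-fold lower number from compound 3 to compound 4 (0.35 log units; beyond the scatter). For compound 4 the estimate is 55000 nM, with an expected range from 20000 nM to 125000 nM.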

Compound 4, half-maximal inhibitory concentration: 50000 nM
Compound 4: middle estimate off by 1.1-fold (0.04 log units), on the high side, and the stated range covers the measured number.
By their numbers in this assay, from the lowest: compound 1; then compounds 2 and 4 (each within the scatter of the next). At a limit, above all of these: compound 3.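

Compound 3 gives a limit, not a number, and an at least 2.5-fold lower number from compound 3 to compound 4 (0.39 log units; beyond the scatter) shows that where the methoxy sits matters, not only whether it is present. Against the unsubstituted phenyl, 3-methoxyphenyl gives a 1.4-fold higher number from compound 2 to compound 4 (0.14 log units; within the scatter), so in these compounds only 2-methoxyphenyl stands clearly apart. The hydroxy group also counts alongside 3-methoxyphenyl, with a 5.0-fold higher number from compound 1 to compound 4 (0.70 log units; beyond the scatter).

Still open, from the compounds shown here alone, is how 4-methoxyphenyl would compare. So is whether an amine or a carboxylic acid in place of the methoxy would follow the same trend.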